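From Isopropyl to Pentan-3-yl at a Clearance Limit

The source may report more compounds than this note shows. Statements on the series, on what has been measured and on what is new or still open speak of the compounds shown alone.

In an ADME assay on microsomes from liver (Rattus norvegicus) for metabolic stability (on this read-out lower numbers stand for slow clearance and higher numbers for fast clearance), compound 1 `CC(C)Oc1cc(Oc2cnc(C(=O)N(C)C)nc2)cc(-c2nccc(=O)[nH]2)c1` is reported only as a limit, < 25.4 mL/min/kg. Compound 2 `CC(C)Oc1cc(Oc2ccc(S(C)(=O)=O)cc2)cc(-c2ncc(Cl)c(=O)[nH]2)c1` is likewise reported only as a limit, < 25.4 mL/min/kg. The measurements so far amount to the limit of < 25.4 mL/min/kg in this assay, at which 2 of the 2 values shown sit, so neither compound has an exact number in this assay.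

Compound 3 `CCC(CC)Oc1cc(Oc2cnc(C(=O)N(C)C)nc2)cc(-c2nccc(=O)[nH]2)c1` keeps the core of compound 1 but carries pentan-3-yl in place of isopropyl on an oxygen on an aromatic ring. No two measured compounds differ in only one place, so the size of this change in this assay has not been shown directly. The expectation therefore rests on the structural change and on the starting limit of compound 1, < 25.4 mL/min/kg. A modest move toward faster clearance seems more likely than no change, although compound 3 could still remain at the limit. The expected step of an at least 1.2-fold higher number from compound 1 to compound 3 (0.10 log units; that floor lies within the scatter) is small and upward. For compound 3, the estimated clearance is 32 mL/min/kg, with an expected range from 22 mL/min/kg to 65 mL/min/kg.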

Compound 3, clearance: 91 mL/min/kg
Estimate against measurement, compound 3: 2.8-fold (0.45 log units) below, and the stated range ends below it.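

Within the data shown here, replacing isopropyl with pentan-3-yl on an oxygen on an aromatic ring gives the first readable step in this assay, an at least 3.5-fold higher number from compound 1 to compound 3 (0.55 log units; beyond the scatter). Compound 1 is reported only as a limit, < 25.4 mL/min/kg. The group on this oxygen therefore matters for clearance on the core of compound 1, and compound 3 is the only compound shown that stands clear of the limit: the limit of < 25.4 mL/min/kg in this assay, at which 2 of the 3 values shown sit.

The compounds shown leave open how clearance would respond to a smaller or differently shaped group on this oxygen, such as methyl, cyclopropyl or tert-butyl, and thus whether the rise follows the growth of the chain or is particular to pentan-3-yl. As far as these compounds go, whether the same exchange would give a step of similar size on the core of compound 2 also remains open.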